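Notes on compound 4: acyl group on the ring nitrogen

This account rests on a few compounds, and the source may have more. Where it says the series, first, only, none or still open, it means among the compounds named here.

Compound 1 `COC(=O)C1=C(C)NC(=O)NC1c1cccc([N+](=O)[O-])c1` gives 18900 nM in an assay on HEK293 cells for antagonist activity at Voltage-dependent L-type calcium channel subunit alpha-1D (Rattus norvegicus), read by FLIPR; on this read-out lower numbers stand for stronger inhibition and higher numbers for weaker inhibition. Compound 3 `CC1=C(C(=O)OC(C)C)C(c2cccc([N+](=O)[O-])c2)NC(=S)N1` gives 15800 nM in this assay; these two values lie within the scatter of each other. Compound 2 `COC(=O)C1=C(C(C)C)NC(=O)NC1c1cccc([N+](=O)[O-])c1` returns > 100000 nM in this assay, which is the limit of the measurement and not a number (the limit of > 100000 nM in this assay, at which 1 of the 3 values shown sits). Among the measured compounds shown here, the one measured step, an at least 5.2-fold higher number from compound 1 to compound 2 (0.72 log units; beyond the scatter), comes from isopropyl in place of methyl on a double-bonded ring carbon.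

Compound 4 `COC(=O)C1=C(C(C)C)NC(=O)N(C(=O)C(C)C)C1c1cccc([N+](=O)[O-])c1` differs from compound 2 as follows: isopropylcarbonyl in place of hydrogen on an amide-type nitrogen in a ring. For the measured compounds named here, no measured pair changes anything on the ring nitrogen, so no step bears directly on this change; the step from compound 1 to compound 2 touches another part of the core and only shows that compound 2 starts at the limit. Going by the values given here, with no direct precedent, the expected step that the limit leaves unreadable from compound 2 to compound 4 is set as none beyond the scatter. Compound 4 is therefore estimated at 150000 nM, between 40000 nM and 600000 nM, with a strong chance that this assay again returns only a limit.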

Compound 4, half-maximal inhibitory concentration: > 100000 nM
Compound 4: only a limit was reported (the forecaster's own chance of this, stated with the estimate: 70%); the middle value is on the limit's open side.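

Compound 4 returns > 100000 nM in this assay, which is a limit and not a number. Compound 2 stands at a limit too, so no step can be read between them. The compounds shown leave open what isopropylcarbonyl on the ring nitrogen does where the parent compound has a measurable value.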